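A few compounds are considered here, and "the series" means these few. Any claim that something is new, unique, unknown or untested is made for them only; others in the source may bear on it.

Notes on the series. The shared core is shown by compound 1, `O=C(O)c1cnc(-c2ccccc2F)[nH]c1=O`; in a functional assay on the whole organism (strain Sprague-Dawley) for inhibition, with Rattus norvegicus as the target, with a stated time of 10 min (on this read-out lower numbers stand for an effect already at smaller amounts and higher numbers for an effect only at larger amounts of compound), compound 1 gives 5 mg/kg. Compound 2, `CCCOc1ccccc1-c1ncc(C(=O)O)c(=O)[nH]1`, carries propoxy in place of fluoro on an aromatic carbon, and in this assay compound 2 gives 0.9 mg/kg, so that a 5.6-fold lower number from compound 1 to compound 2 (0.74 log units; beyond the scatter). Compound 3, `CCOC(=O)c1cnc(-c2ccccc2F)[nH]c1=O`, carries ethyl in place of hydrogen on an oxygen next to a carbonyl group, and an at least 2.0-fold higher number from compound 1 to compound 3 (0.30 log units; that floor lies within the scatter). For compound 3 this assay reports only a limit, > 10 mg/kg, and not a number. Within the numbers shown compound 3 therefore stands at the limit of > 10 mg/kg in this assay, at which 1 of the 3 values shown sits, with no value to set beside the others.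

Compound 4, `CCOC(=O)c1cnc(-c2ccccc2OCC(C)C)[nH]c1=O`, is not yet measured. It differs from compound 3 by isobutoxy in place of fluoro on an aromatic carbon. Within the data shown here, the one measured step that bears on this change is a 5.6-fold lower number from compound 1 to compound 2 (0.74 log units; beyond the scatter), an alkoxy group entering where fluoro stood and giving a modest shift to a lower number beyond the scatter. The change from compound 3 to compound 4 is of the same kind, isobutoxy in place of fluoro, so a step of similar size toward a lower number is expected, an at least 2.5-fold lower number from compound 3 to compound 4 (0.39 log units; beyond the scatter), although the starting point is only a limit. For compound 4 the expected value in this assay is 4 mg/kg, within 1 mg/kg and 20 mg/kg.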

Compound 4, dose for 50% inhibition: 3 mg/kg
For compound 4 the middle estimate is 1.3-fold (0.12 log units) above the measured one, and the stated range covers the measured number.
By their numbers in this assay, from the lowest: compound 2; then compounds 4 and 1 (each within the scatter of the next). At a limit, above all of these: compound 3.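

In this assay, isobutoxy in place of fluoro on the aromatic carbon, ortho to a large group, gives an at least 3.3-fold lower number from compound 3 to compound 4 (0.52 log units; beyond the scatter), so a shift to a lower number beyond the scatter is now seen with the ethyl ester and not only with the free acid. The earlier step, a 5.6-fold lower number from compound 1 to compound 2 (0.74 log units; beyond the scatter), involved propoxy on the free acid, and the two steps agree in direction across two different alkoxy groups, with no compound shown going against this. Compound 3 is reported only as a limit, so the new step is a floor and its true size cannot be set against the earlier one: the limit of > 10 mg/kg in this assay, at which 1 of the 4 values shown sits.

No pair among the compounds shown carries the same alkoxy group as both free acid and ethyl ester, so the effect of the ester with an alkoxy group in place and the difference between propoxy and isobutoxy both remain unseparated. On these data alone, whether an amine, a hydroxyl or a longer alkoxy chain in place of fluoro would shift the number the same way also stays open.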